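A few compounds are considered here, and "the series" means these few. Any claim that something is new, unique, unknown or untested is made for them only; others in the source may bear on it.

Measured so far:
- compound 1 `Cc1ccccc1C(=O)NCc1ccc(CNS(=O)(=O)c2ccccc2)cc1`: 1 nM
- compound 2 `O=C(NCc1ccc(CNS(=O)(=O)c2ccccc2)cc1)c1ccccc1`: 1 nM

In an assay on MDA-MB-231 cells for binding affinity to C-X-C chemokine receptor type 4 (Homo sapiens), read by immunofluorescence and microscopy, with stated times of 10 min and 30 min (a lower number here means that less compound is needed, a higher number that more compound is needed for the effect), compound 2 gives 1 nM, level with compound 1, which gives 1 nM. Among the compounds with values here, the one measured step, hydrogen in place of methyl on an aromatic carbon, gave no change at the digits printed from compound 1 to compound 2 (within the scatter). Compound 3 `COc1cccc(C(=O)NCc2ccc(CNS(=O)(=O)c3ccccc3)cc2)c1` differs from compound 2 by methoxy in place of hydrogen on an aromatic carbon. That earlier step, a small group swapped on the same ring, bears on it and was flat, so a step of similar size is expected here: no change at the digits printed from compound 2 to compound 3 (within the scatter). Compound 3 is therefore expected at 1 nM, within 0.4 nM to 3 nM.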

Compound 3, effective concentration (reported as EC, without a stated level of effect): > 1000 nM
Compound 3 was reported as a limit; the forecaster's own chance of this, stated with the estimate: 5%; middle value at least 1000-fold (3.00 log units) away from the limit.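

In this assay, the ring that showed no response to losing a methyl group responds sharply to another small change: methoxy in place of hydrogen gave an at least 1000-fold higher number from compound 2 to compound 3 (3.00 log units; beyond the scatter), and 3-methoxyphenyl in place of 2-methylphenyl gave an at least 1000-fold higher number from compound 1 to compound 3 (3.00 log units; beyond the scatter). Compound 3 gives > 1000 nM, which is a limit of the assay and not a number. A single methoxy, meta to a large group, is therefore enough to lose the activity of the series at this end of the molecule.

As far as these compounds go, whether this loss belongs to methoxy itself or to its place on the ring stays open. A hydroxyl group or an amine at the same place, or methoxy on another carbon of the ring, would separate the two.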